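A few compounds are considered here, and "the series" means these few. Any claim that something is new, unique, unknown or untested is made for them only; others in the source may bear on it.

In a functional assay on MDA-MB-468 cells (Homo sapiens) for inhibition, read by CCK-8 assay and cell counting, with a stated time of 2 days (a higher number here means a weaker inhibitor, a lower number a stronger inhibitor), compound 1 `O=C(/C=C/c1ccco1)c1ccccc1OCC1CO1` gives 48300 nM and compound 2 `O=C(/C=C/c1ccco1)c1cccc(OCC2CO2)c1` gives 37300 nM. These two values lie within the usual scatter of each other, so compound 2 stands level with compound 1 on the numbers available. Compound 3 `O=C(/C=C/c1cccs1)c1cccc(OCC2CO2)c1` differs from compound 2 in one place: thiophen-2-yl in place of furan-2-yl on a double-bonded chain carbon bound to a double-bonded chain carbon. Going by the values given here, no measured pair shows this swap, so there is little to go on, and no change beyond the scatter is expected in this assay. The expected size of the move is a 1.2-fold lower number from compound 2 to compound 3 (0.09 log units; within the scatter). For compound 3 the estimated value is 30000 nM, with an expected range of 11000 nM to 65000 nM.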

Compound 3, half-maximal inhibitory concentration: 16300 nM
Compound 3: middle estimate off by 1.8-fold (0.26 log units), on the high side, within the range that was stated.
By their numbers in this assay, from the lowest: compound 3; then compounds 2 and 1 (each within the scatter of the next).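

In this assay, the group on the double-bonded chain carbon clearly matters: thiophen-2-yl in place of furan-2-yl gives a 2.3-fold lower number from compound 2 to compound 3 (0.36 log units; beyond the scatter). The two groups have the same number of heavy atoms, and the ring keeps its size, with sulfur in place of oxygen, so this one-atom swap is enough to move the number beyond the scatter. Nothing available here accounts for the move.

As far as these compounds go, whether a phenyl or a thiophen-3-yl group at this place would lower the number further remains open. So does whether the same swap would have a similar effect on the core of compound 1.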